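The source may report more compounds than this note shows. Statements on the series, on what has been measured and on what is new or still open speak of the compounds shown alone.

Measured so far in a functional assay on HepG2 cells (Homo sapiens) for cytotoxicity, read by MTT assay, with a stated time of 48 h; on this read-out higher numbers stand for weaker inhibition and lower numbers for stronger inhibition:
Compound 1 `O=C(CSc1nnc(-c2ccncc2)o1)N/N=C/c1ccc(O)cc1` gives 5510 nM.
Compound 2 `COc1ccc(/C=N/NC(=O)CSc2nnc(-c3ccncc3)o2)cc1` gives 15800 nM.
Compound 3 `O=C(CSc1nnc(-c2ccncc2)o1)N/N=C/c1cc(Br)cc(Br)c1O` gives 6540 nM.

Compound 3 stands second highest of the three numbers in this assay. It sits within the scatter of compound 1, as a 1.2-fold higher number from compound 1 to compound 3 (0.07 log units; within the scatter) shows, and apart from compound 2, as a 2.4-fold lower number from compound 2 to compound 3 (0.38 log units; beyond the scatter) shows.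

The step under consideration leads to compound 4 `COc1cc(/C=N/NC(=O)CSc2nnc(-c3ccncc3)o2)ccc1O`: 4-hydroxy-3-methoxyphenyl in place of 3,5-dibromo-2-hydroxyphenyl on a carbon with a double bond to nitrogen. Within the data shown here, no measured pair makes this exact change, so the bearing steps are indirect. The step of a 2.9-fold higher number from compound 1 to compound 2 (0.46 log units; beyond the scatter) shows the effect of methyl in place of hydrogen on an oxygen on an aromatic ring when no free hydroxyl remains; compound 4 keeps a hydroxyl and adds a methoxy, so any shift may fall between that step and none at all. The steps of a 1.2-fold higher number from compound 1 to compound 3 (0.07 log units; within the scatter) and a 2.4-fold lower number from compound 2 to compound 3 (0.38 log units; beyond the scatter) show that the 3,5-dibromo-2-hydroxyphenyl of compound 3 and the 4-hydroxyphenyl of compound 1 give numbers within the scatter of each other, so the exchange of the dibromo ring for a hydroxy-bearing ring should by itself move the number little.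

Compound 4 is therefore expected near 8000 nM, with a range from 3500 nM to 18000 nM. For compound 4 the expected step is a 1.2-fold higher number from compound 3 to compound 4 (0.09 log units; within the scatter), most likely within the scatter or at most modest, leaning toward a higher number.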

Compound 4, half-maximal inhibitory concentration: 2920 nM
Compound 4: the middle estimate sits 2.7-fold (0.44 log units) above what was measured; the whole stated range lies above it.
By their numbers in this assay, from the lowest: compounds 4, 1 and 3 (each within the scatter of the next, the first and the last beyond it); then compound 2.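

In this assay, the 4-hydroxy-3-methoxyphenyl on a carbon with a double bond to nitrogen now stands apart from the 3,5-dibromo-2-hydroxyphenyl, with a 2.2-fold lower number from compound 3 to compound 4 (0.35 log units; beyond the scatter), while a 1.9-fold lower number from compound 1 to compound 4 (0.28 log units; within the scatter) gives the added methoxy on the 4-hydroxyphenyl no readable effect. A methoxy on this ring therefore does not by itself go with the high number of compound 2: with a hydroxyl kept on the ring, the series shows a 5.4-fold lower number from compound 2 to compound 4 (0.73 log units; beyond the scatter), and compound 1, compound 3 and compound 4, the three that carry a hydroxyl, all lie lower than compound 2, beyond the scatter. The data at hand offer no measurement that would explain these steps.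

As far as these compounds go, whether the hydroxyl itself is needed remains open, as the only ring without one, in compound 2, also carries a methoxy, and a plain phenyl or a ring bearing an amine or a carboxylic acid in that place would separate the two. Also open, from the compounds shown here alone, is how far the ring tolerates larger groups, such as an ethoxy or a longer alkoxy chain in place of the methoxy of compound 4.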